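This account rests on a few compounds, and the source may have more. Where it says the series, first, only, none or still open, it means among the compounds named here.

Measured so far in an assay on isolated protein for inhibition of lysosomal alpha-glucosidase (Rattus norvegicus), read by colorimetric assay; a lower number here means a stronger inhibitor, a higher number a weaker inhibitor:
compound 1 `COc1ccc([C@]2(CO)NC[C@@H](O)[C@@H]2O)cc1`: 395000 nM
compound 2 `COc1ccc([C@@]2(CO)NC[C@H](O)[C@H]2O)cc1`: 2100 nM
compound 3 `Cc1ccc([C@@]2(CO)NC[C@H](O)[C@H]2O)cc1`: 17000 nM

Compound 2 gives the lowest of these three numbers in this assay. The two compounds that flank it show steps of a 190-fold lower number from compound 1 to compound 2 (2.27 log units; beyond the scatter) and an 8.1-fold higher number from compound 2 to compound 3 (0.91 log units; beyond the scatter); the first step is explained by the fact that compounds 1 and 2 differ only in the configuration as drawn. Compound 4 `COc1ccc([C@@]2(CO)NC[C@H](O)[C@H]2O)cc1OC` differs from compound 2 by methoxy in place of hydrogen on an aromatic carbon. Neither measured step covers adding a second methoxy group, so only the modest size of the methoxy-to-methyl step hints at what a change on that ring may do. For compound 4 the estimate in this assay is therefore a step of a 1.4-fold higher number from compound 2 to compound 4 (0.15 log units; within the scatter), with the number expected at 3000 nM, within a range of 700 nM to 13000 nM.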

Compound 4, half-maximal inhibitory concentration: 60000 nM
Compound 4: the middle estimate sits 20-fold (1.30 log units) below what was measured; the whole stated range lies below it.
By their numbers in this assay, from the lowest: compound 2; then compound 3; then compound 4; then compound 1.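

In this assay, methoxy in place of hydrogen on the aromatic carbon ortho to a methoxy group gives a 29-fold higher number from compound 2 to compound 4 (1.46 log units; beyond the scatter), so adding to this position of the ring carries a large penalty. The earlier methoxy-to-methyl change had shown only a modest step, and that gave no sign of a penalty this size. Nothing available here bears on why this step is so large. On these data alone, it remains open whether the loss belongs to this position or to methoxy itself. Whether fluorine or a hydroxyl group on the same carbon behaves likewise is also unknown.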